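The source may report more compounds than this note shows. Statements on the series, on what has been measured and on what is new or still open speak of the compounds shown alone.

Of the compounds shown here, three sharing one core have been measured so far in a functional assay on PC-3 cells (Homo sapiens) for inhibition, read by sulforhodamine B assay, with a stated time of 72 h; a lower number here means a stronger inhibitor, a higher number a weaker inhibitor. Compound 1 `Nc1sc(-c2ccc(Cl)cc2)c(-c2ccc(Cl)cc2)c1C(=O)N1CCCCC1=O` gives 4940 nM and compound 2 `CC1CN(C(=O)c2c(N)sc(-c3ccc(Cl)cc3)c2-c2ccc(Cl)cc2)CCN1` gives 7210 nM while compound 3 `Nc1sc(-c2ccc(Cl)cc2)c(-c2ccc(Cl)cc2)c1C(=O)NC1CCCCC1` gives 7300 nM on the same read-out. Compound 3 has no separate place among them: the step to it from compound 1 is small (a 1.5-fold higher number from compound 1 to compound 3 (0.17 log units; within the scatter)) and so is the step to it from compound 2 (a 1.0-fold higher number from compound 2 to compound 3 (0.01 log units; within the scatter)).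

Compound 4 `CC1CCN(C(=O)c2c(N)sc(-c3ccc(Cl)cc3)c2-c2ccc(Cl)cc2)CC1` keeps that core and alters only the group on a carbonyl carbon (4-methylpiperidin-1-yl in place of cyclohexylamino on a carbonyl carbon). In words, 4-methylpiperidin-1-yl stands in place of cyclohexylamino, with the same atoms joined differently.

Among the compounds with values here, no measured step makes exactly this swap. The closest evidence comes from the other exchanges on that carbonyl carbon. These are the swap of 2-oxopiperidin-1-yl for 3-methylpiperazin-1-yl (a 1.5-fold higher number from compound 1 to compound 2 (0.16 log units; within the scatter)) and the two steps already given above. None of the three leaves the scatter, so no step beyond the scatter is expected in this assay and no direction can be called with confidence. The expected step is small (a 1.2-fold lower number from compound 3 to compound 4 (0.09 log units; within the scatter)). The estimated value for compound 4 is 6000 nM with an expected range from 3000 nM to 12000 nM overall.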

Compound 4, half-maximal inhibitory concentration: 5750 nM
Beside the measured number, compound 4's estimate is 1.0-fold (0.02 log units) above it; the measured number falls inside the stated range.
By their numbers in this assay, from the lowest: compounds 1, 4, 2 and 3 (each within the scatter of the next).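

Compound 4 adds a new kind of contrast to the series: cyclohexylamino has 1 hydrogen-bond donor and a ring of carbon only, while 4-methylpiperidin-1-yl has 0 donors and its nitrogen within the ring, yet in this assay this exchange stays within the scatter (a 1.3-fold lower number from compound 3 to compound 4 (0.10 log units; within the scatter)). The other two new comparisons on this carbonyl carbon are also within the scatter, one against the 3-methylpiperazin-1-yl group (a 1.3-fold lower number from compound 2 to compound 4 (0.10 log units; within the scatter)) and one against the 2-oxopiperidin-1-yl group (a 1.2-fold higher number from compound 1 to compound 4 (0.07 log units; within the scatter)), so no compound among these four goes against a flat picture at this position. No measurement is at hand that could explain this flat picture.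

Every group shown here on the carbonyl carbon is built around a ring of six atoms, so it remains open whether a carboxylic acid or a longer chain, such as octylamino, would give a step beyond the scatter. The rest of the shared core is the same in all four compounds, so these results also say nothing about a change there, such as fluorine in place of chlorine.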